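A few compounds are considered here, and "the series" means these few. Any claim that something is new, unique, unknown or untested is made for them only; others in the source may bear on it.

Measured so far:
compound 1, `NC(=S)N/N=C1/C(=O)N(CN2CCN(c3ccnc4cc(Cl)ccc34)CC2)c2cccc(Br)c21`: in an ADME assay on MCF-10A cells (Homo sapiens) for cytotoxicity, read by sulforhodamine B assay, with a stated time of 48 h (a higher number here means a weaker inhibitor of growth, a lower number a stronger inhibitor of growth), compound 1 gives 29400 nM
compound 2, `NC(=S)N/N=C1/C(=O)N(CN2CCN(c3ccnc4cc(C(F)(F)F)ccc34)CC2)c2cccc(Cl)c21`: in this assay compound 2 gives 51700 nM

Compound 2 has the higher of the two numbers in this assay, but its gap to compound 1 lies within the scatter, so the two read alike. Compound 3, `NC(=S)N/N=C1/C(=O)N(CN2CCN(c3ccnc4cc(C(F)(F)F)ccc34)CC2)c2cccc(Br)c21`, differs from compound 2 by bromo in place of chloro on an aromatic carbon. For the measured compounds named here, no measured pair shows this change, so nothing in the numbers fixes its size or direction; a shift no larger than the scatter of this assay is the natural expectation. Compound 3 is therefore estimated at 45000 nM, between 20000 nM and 100000 nM. That estimate means an expected step of a 1.1-fold lower number from compound 2 to compound 3 (0.06 log units; within the scatter), within the scatter.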

Compound 3, concentration for 50% growth inhibition: 30600 nM
Estimate against measurement, compound 3: 1.5-fold (0.17 log units) above; measured number inside the range.
By their numbers in this assay, from the lowest: compounds 1, 3 and 2 (each within the scatter of the next).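

In this assay, bromo in place of chloro on this aromatic carbon, ortho to a fused ring, gives a 1.7-fold lower number from compound 2 to compound 3 (0.23 log units; within the scatter) and so leaves compounds with the trifluoromethyl group reading alike. Exchanging chloro on an aromatic carbon for trifluoromethyl, with bromo held fixed, gives a 1.0-fold higher number from compound 1 to compound 3 (0.02 log units; within the scatter) and likewise separates nothing. No measurement at hand accounts for these readings. Still open, from the compounds shown here alone, is whether an amine or a carboxylic acid on the bromo-bearing carbon would carry the number beyond the scatter.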